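Removing a Hydroxy Group from the Amine Substituent

This account rests on a few compounds, and the source may have more. Where it says the series, first, only, none or still open, it means among the compounds named here.

Of the compounds shown here, three with a shared core have been measured in an assay on isolated protein for binding affinity to adenosine receptor A1 (Bos taurus); on this read-out higher numbers stand for weaker inhibition and lower numbers for stronger inhibition. Compound 1 `CCCCNc1nc(-c2ccccc2)nc2c1nnn2Cc1ccccc1F` gives 4300000 nM. Compound 2 `O[C@H]1CCCC[C@@H]1Nc1nc(-c2ccccc2)nc2c1nnn2Cc1ccccc1` gives 10300000 nM, which is the second highest of the three numbers: compound 1 is its nearest neighbour, and compound 3 `OCCNc1nc(-c2ccccc2)nc2c1nnn2Cc1ccccc1F` gives 54000000 nM, the furthest from it. Within the data shown here, the one measured step between compounds that differ in a single place is a 13-fold higher number from compound 1 to compound 3 (1.10 log units; beyond the scatter), which shows that introducing a hydroxy group onto the chain on the ring nitrogen made the number much higher.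

Compound 4 `c1ccc(Cn2nnc3c(NC4CCC4)nc(-c4ccccc4)nc32)cc1` has not yet been measured. It differs from compound 2 by cyclobutyl in place of 2-hydroxycyclohexyl on a nitrogen on an aromatic ring, so the hydroxy group of compound 2 is lost along with two ring carbons. Because the step of a 13-fold higher number from compound 1 to compound 3 (1.10 log units; beyond the scatter) runs in the opposite direction, a lower number is expected for compound 4 in this assay, with the change from compound 2 to compound 4 estimated at a 3.4-fold lower number from compound 2 to compound 4 (0.54 log units; beyond the scatter). The value of compound 4 is therefore estimated at 3000000 nM, within a range from 800000 nM to 12000000 nM.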

Compound 4, inhibition constant: 5000000 nM
Estimate against measurement, compound 4: 1.7-fold (0.22 log units) below, and the stated range covers the measured number.
By their numbers in this assay, from the lowest: compounds 1 and 4 (each within the scatter of the next); then compound 2; then compound 3.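

On the nitrogen on an aromatic ring, replacing 2-hydroxycyclohexyl with cyclobutyl gives a 2.1-fold lower number from compound 2 to compound 4 (0.31 log units; beyond the scatter) in this assay. This is a second single-place change that removes a hydroxy group and lowers the number, now with a ring-bearing substituent rather than a straight chain, and no compound shown goes against that direction. Nothing available here explains this step.

The change also swaps a six-membered ring for a four-membered one, so the compounds shown leave open whether the step goes with losing the hydroxy group, with the ring change, or with both. A plain cyclohexyl group on the same nitrogen would separate the two, since it keeps the six-membered ring and lacks the hydroxy group.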